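Series notes: benzyloxy variation ahead of compound 3

The source may hold more compounds than are shown below. What is called first, only, known or untested is meant among the compounds shown, and "the series" means these compounds.

Measured so far:
compound 1 `COc1ccccc1COc1ccc(Br)cc1Cn1nc(C(=O)O)cc1C` gives 69.2 nM in a functional assay on CHO-K1 cells for antagonist activity at prostaglandin E2 receptor EP1 subtype (Homo sapiens), read by FLIPR; on this read-out higher numbers stand for weaker inhibition and lower numbers for stronger inhibition
compound 2 `Cc1cc(C(=O)O)nn1Cc1cc(Br)ccc1OCc1cccc(Cl)c1` gives 427 nM in this assay

Among the compounds with values here, compound 2 stands highest of the two numbers so far; its nearest neighbour is compound 1, and the step of a 6.2-fold higher number from compound 1 to compound 2 (0.79 log units; beyond the scatter) is the only measured step in the set. Compound 3 `Cc1cc(C(=O)O)nn1Cc1cc(Br)ccc1OCc1cccc([N+](=O)[O-])c1` differs from compound 2 by nitro in place of chloro on an aromatic carbon, a change on an aromatic carbon of a six-membered aromatic ring of carbon only, meta to a large group. Within the data shown here, no measured step bears directly on a nitro for chloro exchange; the one step recorded concerns a different part of the molecule, so it gives no guide to the direction here. With nothing to lean on, the expectation for this assay is a step of a 1.0-fold higher number from compound 2 to compound 3 (0.00 log units; within the scatter), that is, no change beyond the scatter. Compound 3 is therefore estimated at 430 nM, with a range from 130 nM to 1400 nM.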

Compound 3, inhibition constant: 339 nM
The estimate for compound 3 lay 1.3-fold (0.10 log units) above the measured number; low and high end bracket the measured number.
By their numbers in this assay, from the lowest: compound 1; then compounds 3 and 2 (each within the scatter of the next).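

In this assay, nitro in place of chloro on this aromatic carbon, meta to a large group, gives a 1.3-fold lower number from compound 2 to compound 3 (0.10 log units; within the scatter), so at this position the read-out does not separate the two groups, although nitro brings more heavy atoms and hydrogen-bond acceptors than chloro. The 3-nitrophenyl compound also stays apart from the 2-methoxyphenyl compound, with a 4.9-fold higher number from compound 1 to compound 3 (0.69 log units; beyond the scatter), a step of similar size to a 6.2-fold higher number from compound 1 to compound 2 (0.79 log units; beyond the scatter), so the gap to compound 1 does not depend on which of these two groups is present. Nothing available accounts for this lack of separation.

From the compounds shown here alone, whether the lower number of compound 1 goes with methoxy itself or with its place on the ring remains open, as both differ in each step from it. An amine on the carbon that carries chloro or nitro would show whether the same result extends beyond these two groups.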